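The source may hold more compounds than are shown below. What is called first, only, known or untested is meant among the compounds shown, and "the series" means these compounds.

Compound 2 `CC(Oc1ccccc1OC1CC1)C1=NCCN1` gives 12900 nM in a functional assay on CHO cells for agonist activity at Alpha-2B adrenergic receptor (Homo sapiens); a lower number here means that less compound is needed, a higher number that more compound is needed for the effect. Among the two compounds measured, compound 2 holds the highest number, and its nearest neighbour is compound 1 `CCc1ccccc1OC(C)C1=NCCN1`, which gives 10000 nM in this assay; the step of a 1.3-fold higher number from compound 1 to compound 2 (0.11 log units; within the scatter) lies within the scatter, so nothing can be said about an order between them. Compound 3 `COc1ccccc1OC(C)C1=NCCN1` differs from compound 2 by methyl in place of cyclopropyl on an oxygen on an aromatic ring. For the measured compounds named here, no measured step covers this exchange: the one step known, from ethyl to cyclopropyloxy, touches a different part of the structure and was itself within the scatter. Going by the values given here, with only two numbers so close together, the step of a 1.3-fold lower number from compound 2 to compound 3 (0.11 log units; within the scatter) is expected to stay within the scatter as well. Compound 3 is therefore estimated at 10000 nM in this assay, with a range from 4000 nM to 30000 nM.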

Compound 3, half-maximal effective concentration: 100000 nM
Estimate against measurement, compound 3: 10-fold (1.00 log units) below; measured number outside the range, above it.
By their numbers in this assay, from the lowest: compounds 1 and 2 (each within the scatter of the next); then compound 3.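

In this assay, the group on the oxygen on an aromatic ring makes a clear difference: methyl in place of cyclopropyl moves the number beyond the scatter (a 7.8-fold higher number from compound 2 to compound 3 (0.89 log units; beyond the scatter)). Methoxy in place of ethyl on an aromatic carbon also gives a step beyond the scatter (a 10-fold higher number from compound 1 to compound 3 (1.00 log units; beyond the scatter)), so methoxy stands apart from two groups whose own numbers could not be ordered. Nothing available explains why the number rises with this exchange.

The compounds shown leave open whether ethoxy or a longer chain on that oxygen would read like cyclopropyloxy or like methoxy, and so whether the three-membered ring itself matters or only the number of carbons. They also do not tell how an amine or a hydroxyl group would read at this place.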